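Hydrogen in Place of Hydroxymethyl: Expecting Another Limit

The source may report more compounds than this note shows. Statements on the series, on what has been measured and on what is new or still open speak of the compounds shown alone.

Compound 1 `CC(=O)O[C@@H]1[C@@H](OC(C)=O)[C@@H](O)CO[C@H]1NC(=S)NNC(=O)Cn1cnc2c(N)ncnc21`: > 100000 nM
Compound 2 `CC(=O)O[C@@H]1[C@@H](OC(C)=O)[C@H](O)[C@@H](CO)O[C@H]1NC(=S)NNC(=O)Cn1cnc2ccccc21`: > 100000 nM
Compound 3 `CC(=O)O[C@@H]1[C@@H](OC(C)=O)[C@@H](O)[C@@H](CO)O[C@H]1NC(=S)NNC(=O)Cn1cnc2ccccc21`: > 200000 nM

In a functional assay on Bel-7402 cells (Homo sapiens) for cytotoxicity, read by MTT assay, with a stated time of 48 h (a higher number here means that more compound is needed for the effect, a lower number that less compound is needed), compound 1 gives only a limit, > 100000 nM. Compound 2 likewise gives only a limit, > 100000 nM. Compound 3 also stands at a limit, > 200000 nM, so no number is known for it. The step that the two limits leave unreadable from compound 2 to compound 3 cannot be read in size, because the limit of > 100000 nM in this assay, at which 2 of the 3 values shown sit, and the limit of > 200000 nM in this assay, at which 1 of the 3 values shown sits, are both limits, even though the fact that compounds 2 and 3 differ only in the configuration as drawn makes the pair a clean comparison.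

Compound 4 `CC(=O)O[C@@H]1[C@@H](OC(C)=O)[C@@H](O)CO[C@H]1NC(=S)NNC(=O)Cn1cnc2ccccc21` differs from compound 3 by hydrogen in place of hydroxymethyl on a saturated ring carbon. Going by the values given here, no measured step touches this change, and every measured value here is a limit. Compound 4 is therefore expected to sit at a limit as well, a step of a number no higher from compound 3 to compound 4 (the limit leaves the size open) of no readable size. Compound 4 is estimated at 200000 nM in this assay, between 80000 nM and 600000 nM.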

Compound 4, half-maximal effective concentration: > 200000 nM
Compound 4 was reported as a limit; the forecaster's own chance of this, stated with the estimate: 85%; the middle value lies on the limit itself.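

In this assay compound 4 gives only a limit, so its steps from compound 3 and from compound 1 cannot be read in size. The compounds shown leave open whether hydrogen in place of hydroxymethyl changes the amount needed for the effect.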